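The compounds below may be only part of what the source reports. "The series", "measured", "known", "first", "only" and "open" are said of these compounds alone.

Two thiazolidinedione ethers carrying a substituted aryloxy group have been measured in a functional assay for agonist activity at Free fatty acid receptor 1 (Homo sapiens), read by FLIPR, in the presence of a further agent that is not named here; a higher number here means that more compound is needed for the effect, a lower number that less compound is needed. Compound 1 `Cc1cccc(Oc2ccc(CC3SC(=O)NC3=O)cc2)n1` gives 2620 nM in this assay. Compound 2 `O=C1NC(=O)C(Cc2ccc(Oc3ccc(Cl)cn3)cc2)S1` gives 1870 nM in this assay. Within the data shown here, the only step available, a 1.4-fold lower number from compound 1 to compound 2 (0.15 log units; within the scatter), exchanges one substituted pyridyl for another and does not separate the two compounds. Compound 2 therefore gives the lowest of the two numbers, with compound 1 its nearest neighbour and within the scatter of it.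

Compound 3 `O=C1NC(=O)C(Cc2ccc(Oc3ccc(Cl)cc3)cc2)S1` has not yet been measured in this assay. It differs from compound 2 in one place: 4-chlorophenyl in place of 5-chloropyridin-2-yl on an oxygen on an aromatic ring. Among the measured compounds shown here, no measured step here bears directly on an exchange of a pyridine ring for a carbon-only ring; the sole step, a 1.4-fold lower number from compound 1 to compound 2 (0.15 log units; within the scatter), concerns two pyridyl variants and was itself within the scatter. With nothing in the measured pairs to suggest a shift beyond the scatter, compound 3 is expected to sit near compound 2, so that the estimated step of a 1.0-fold higher number from compound 2 to compound 3 (0.01 log units; within the scatter) is essentially flat. The estimate for compound 3 in this assay is 1900 nM, with a range from 600 nM to 6000 nM.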

Compound 3, half-maximal effective concentration: 240 nM
For compound 3 the middle estimate is 7.9-fold (0.90 log units) above the measured one, outside the stated range (below it).
By their numbers in this assay, from the lowest: compound 3; then compounds 2 and 1 (each within the scatter of the next).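

In this assay, among these compounds, replacing 5-chloropyridin-2-yl with 4-chlorophenyl on an oxygen on an aromatic ring gives a 7.8-fold lower number from compound 2 to compound 3 (0.89 log units; beyond the scatter) and is the first change to fall beyond the scatter, whereas the exchange of one pyridyl group for the other gave only a 1.4-fold lower number from compound 1 to compound 2 (0.15 log units; within the scatter) and separated nothing. Replacing 6-methylpyridin-2-yl with 4-chlorophenyl at the same place gives an 11-fold lower number from compound 1 to compound 3 (1.04 log units; beyond the scatter) as well, so this position does respond to its aryl group, and both compounds with a pyridine ring stand apart from compound 3, which has a six-membered aromatic ring of carbon only. No measurement on hand explains the size of these steps.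

Compound 3 is the only compound here with a carbon-only ring at this position, so the compounds shown leave open whether its lower number depends on the chlorine or would carry over to plain phenyl, 4-methylphenyl or 3-chlorophenyl. They also leave open whether a pyridine ring joined through another ring carbon, such as 6-chloropyridin-3-yl, would stay with compound 2 or move towards compound 3.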